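Fluoro at the pyrrole nitrogen-neighbouring carbon: compound 3 expected

The compounds below may be only part of what the source reports. "The series", "measured", "known", "first", "only" and "open" are said of these compounds alone.

Measured compounds:
compound 1, `CS(=O)(=O)c1ccc(-c2[nH]ccc2-c2ccc(F)cc2)cc1`: > 100 mg/kg
compound 2, `CS(=O)(=O)c1ccc(-c2[nH]c(Cl)c(Br)c2-c2ccc(F)cc2)cc1`: 3.4 mg/kg

Of the compounds shown here, two have been tested in a functional assay on the whole organism with Rattus norvegicus as the target (on this read-out lower numbers stand for an effect already at smaller amounts and higher numbers for an effect only at larger amounts of compound), and a third is to follow. In this assay compound 1 gives > 100 mg/kg, which is a limit of the assay and not a number. Compound 2 gives 3.4 mg/kg in this assay. These two compounds differ in two places, so only their two values can be set side by side: compound 1 sits at the limit, compound 2 at a measured dose. Compound 3, `CS(=O)(=O)c1ccc(-c2[nH]c(F)cc2-c2ccc(F)cc2)cc1`, differs from compound 1 in one place: fluoro in place of hydrogen on an aromatic carbon. Within the data shown here, no measured step matches this single change. Because compound 1 sits at the limit of > 100 mg/kg in this assay, at which 1 of the 2 values shown sits, a move toward smaller doses for compound 3 is expected, beyond the scatter, but smaller than the gap between compound 1 and compound 2. The expected step from compound 1 to compound 3 is an at least 3.3-fold lower number from compound 1 to compound 3 (0.52 log units; beyond the scatter). Compound 3 is estimated at 30 mg/kg, between 8 mg/kg and 120 mg/kg.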

Compound 3, dose for half-maximal effect: 0.31 mg/kg
Compound 3: middle estimate off by 97-fold (1.99 log units), on the high side, and the stated range ends above it.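

The change from compound 1 to compound 3 is a single one, fluoro in place of hydrogen on an aromatic carbon next to the ring nitrogen, and in this assay it gives an at least 320-fold lower number from compound 1 to compound 3 (2.50 log units; beyond the scatter), so this one position alone carries a large step, which the two earlier compounds, differing in two places, could not show. In this assay compound 1 gives > 100 mg/kg, which is a limit of the assay and not a number. The step can therefore be read only as a bound and its full size stays unknown, because the starting value is such a limit: the limit of > 100 mg/kg in this assay, at which 1 of the 3 values shown sits.

The compounds shown leave open whether the step belongs to fluoro itself or would also come with another small group on the same carbon, such as methyl, trifluoromethyl or a nitrile. They also leave open how much of a dose read in the whole organism reflects action at the target and how much reflects what happens to the compound in the animal.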